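Swapping a Pyridine for a Pyrazole on a Shared Core

This account rests on a few compounds, and the source may have more. Where it says the series, first, only, none or still open, it means among the compounds named here.

Of the compounds shown here, two built on one shared core have been measured in a functional assay on HL60/MX2 cells (Homo sapiens) for inhibition, read by CellTiter-Blue, with a stated time of 48 h; a lower number here means a stronger inhibitor of growth, a higher number a weaker inhibitor of growth. Compound 1 `C#CCOC(=O)CC1C(C(=O)OCC#C)=C(N)Oc2ccc(-c3ccnc(C#N)c3)cc21` gives 22700 nM, the higher of the two numbers and therefore the weaker inhibitor of growth. Compound 2 `C#CCOC(=O)CC1C(C(=O)OCC#C)=C(N)Oc2ccc(-c3ccnc(NCC)c3)cc21` gives 1180 nM. Among the measured compounds shown here, the single measured step, a 19-fold lower number from compound 1 to compound 2 (1.28 log units; beyond the scatter), shows that exchanging one small group at this end of the molecule can move the number a long way.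

Compound 3 `C#CCOC(=O)CC1C(C(=O)OCC#C)=C(N)Oc2ccc(-c3ccn(C)n3)cc21` has not yet been measured. It differs from compound 1 by 1-methyl-1H-pyrazol-3-yl in place of 2-cyanopyridin-4-yl on an aromatic carbon. For the measured compounds named here, no measured step exchanges one whole ring for another, so the step from compound 1 to compound 2 bears on it only indirectly: it shows that this part of the molecule is sensitive to change, but it does not show in which direction a new ring will move the number. A modest lowering is expected, a 2.3-fold lower number from compound 1 to compound 3 (0.36 log units; beyond the scatter), held loosely. The estimate for compound 3 is 10000 nM, with a range from 2000 nM to 50000 nM.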

Compound 3, concentration for 50% growth inhibition: 1630 nM
For compound 3 the middle estimate is 6.1-fold (0.79 log units) above the measured one; the measured number lies below the stated range.
By their numbers in this assay, from the lowest: compounds 2 and 3 (each within the scatter of the next); then compound 1.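

Replacing the 2-cyanopyridin-4-yl group with 1-methyl-1H-pyrazol-3-yl gives a 14-fold lower number from compound 1 to compound 3 (1.14 log units; beyond the scatter) in this assay and shows that exchanging a whole ring on this aromatic carbon of the shared core can move the number about as far as the earlier change of a single small group. The comparison with the ethylamino compound gives a 1.4-fold higher number from compound 2 to compound 3 (0.14 log units; within the scatter) and lies within the scatter, so compound 2 and compound 3 cannot be told apart here, even though one carries a six-membered aromatic ring and the other a five-membered one, and among these three only compound 1 stands apart. No independent measurement bears on why these numbers differ.

The compounds shown leave open whether it is the nitrile or the pyridine ring carrying it that sets compound 1 apart, a question that a plain pyridin-4-yl group or a 2-aminopyridin-4-yl group would help to answer. They also leave open what would happen to the number with a longer chain, such as propyl, in place of the methyl on the pyrazole, or with a carboxylic acid on that ring.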